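Bromo for Methyl on Two Related Cores

The compounds below may be only part of what the source reports. "The series", "measured", "known", "first", "only" and "open" are said of these compounds alone.

Of the compounds shown here, three have been tested in a functional assay on SW1573 cells (Homo sapiens) for inhibition, read by sulforhodamine B assay, with a stated time of 48 h; on this read-out higher numbers stand for weaker inhibition of growth and lower numbers for stronger inhibition of growth. Compound 1 `COC(=O)[C@@]1(C)CCC=C2[C@@H]1CC[C@@H](C)[C@]2(C)Cc1c[nH]c2c(C)cccc12` gives 7800 nM. Compound 2 `COC(=O)[C@@]1(C)CCC=C2[C@@H]1CC[C@@H](C)[C@]2(C)Cc1c[nH]c2c(Br)cccc12` differs from it by a single change, (bromo in place of methyl on an aromatic carbon), and gives 14000 nM; the step is a 1.8-fold higher number from compound 1 to compound 2 (0.25 log units; within the scatter). Compound 3 `COC(=O)[C@@]1(C)CC[C@@H]2C3=C1CC[C@@H](C)[C@]3(C)Cc1c2[nH]c2c(C)cccc12` is built on a different core, and the difference between the two cores is not broken down here. In this assay compound 3 gives 16000 nM.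

Compound 4 `COC(=O)[C@@]1(C)CC[C@@H]2C3=C1CC[C@@H](C)[C@]3(C)Cc1c2[nH]c2c(Br)cccc12` has not yet been measured. It stands to compound 3 as compound 2 stands to compound 1: bromo in place of methyl on an aromatic carbon. The surroundings of that place are not identical, though: in compound 1 the ring is part of a fused or bridged system of two rings, in compound 3 part of a fused or bridged system of five rings, so this is the same kind of change rather than the same change. For compound 4 the expected step is a 1.6-fold higher number from compound 3 to compound 4 (0.21 log units; within the scatter), which rests on the measured step of a 1.8-fold higher number from compound 1 to compound 2 (0.25 log units; within the scatter) seen once. Compound 4 is therefore estimated at 26000 nM, with a likely range from 12000 nM to 55000 nM.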

Compound 4, concentration for 50% growth inhibition: 26000 nM
Compound 4: the middle estimate sits on the measured number at the digits printed, and the stated range covers the measured number.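

Putting bromo in place of methyl on the second core gives a 1.6-fold higher number from compound 3 to compound 4 (0.21 log units; within the scatter) in this assay, so this step alone cannot be told apart from the ordinary spread of repeated measurements. Set beside the earlier step, the change gives much the same result on both cores: the same change on two cores in this assay, a 1.8-fold higher number (0.25 log units; within the scatter) from compound 1 to compound 2 and a 1.6-fold higher number (0.21 log units; within the scatter) from compound 3 to compound 4, 1.1-fold (0.04 log units) apart, within the scatter of two such steps. This shows that, for these two pairs, the step carries over from one core to the other with no visible difference, but it does not show that bromo and methyl truly differ in this read-out, nor that the same step would appear on any further core.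

The compounds shown carry only methyl or bromo on this aromatic carbon, so it remains open what a chlorine, a methoxy group or a nitrile would do there. As far as these compounds go, it also remains open whether replacing the methyl ester with a carboxylic acid or an amide would produce a step beyond the scatter in this assay.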